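Swapping Cyano for Methoxy on an Amide

A few compounds are considered here, and "the series" means these few. Any claim that something is new, unique, unknown or untested is made for them only; others in the source may bear on it.

Compound 2 `COc1cccc2cc(C(=O)Nc3c(C#N)ncn3-c3ccc(C#N)cc3)c(=N)oc12` gives 10% in an assay on HEK293 cells for displacement of a labelled ligand from adenosine receptor A2b (Homo sapiens), read by scintillation counting, with a stated time of 30 min, tested at 10 uM (a higher number here means more inhibition at the concentration tested (going by the name of the read-out), a lower number less inhibition), level with compound 1 `N=c1oc2ccc(Br)cc2cc1C(=O)NC1CCCCC1`, which gives 10%; together these two are the lowest of the three numbers, and compound 3 `N=c1oc2ccc(Br)cc2cc1C(=O)NCCO` gives 15%. Among the compounds with values here, the only measured step, a number 5 percentage points higher from compound 1 to compound 3 (within the scatter), concerns a change on the amide-type nitrogen and does not bear on the present change. Compound 4 `COc1ccc(-n2cnc(C#N)c2NC(=O)c2cc3cccc(OC)c3oc2=N)cc1` differs from compound 2 by methoxy in place of cyano on an aromatic carbon. Within the data shown here, no measured pair shows this exchange; all three measured numbers sit low and close together. A step of a number 2 percentage points higher from compound 2 to compound 4 (within the scatter) is therefore expected, staying within the scatter. The estimate for compound 4 is 12%, expected to lie between 0% and 30%.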

Compound 4, a percentage reported as inhibition, at one concentration (the size of the read-out at that concentration, not a potency): 5%
The estimate for compound 4 lay 7 percentage points above the measured number; low and high end bracket the measured number.
By their numbers in this assay, from the lowest: compounds 4, 1, 2 and 3 (each within the scatter of the next).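

Within the data shown here, exchanging cyano for methoxy on the aromatic carbon para to a large group gives a number 5 percentage points lower from compound 2 to compound 4 (within the scatter) in this assay, the only reading of a change at this position. At this single concentration, the assay therefore does not tell the 4-cyanophenyl and 4-methoxyphenyl compounds apart. Nothing available explains this result.

As far as these compounds go, whether an amine or a carboxylic acid at the same position would give a different number remains open. So does whether any group there can lift inhibition clear of the scatter.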